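Benzyl Ester to Primary Amide on the Side Chain

The source may report more compounds than this note shows. Statements on the series, on what has been measured and on what is new or still open speak of the compounds shown alone.

Among the measured compounds shown here, compound 2 `O=C(CN(c1nc(Cl)nc2[nH]cnc12)C1CC1)N[C@@H](CCC(=O)OCc1ccccc1)C(=O)OCc1ccccc1` gives 50% in a functional assay on the whole organism (Tail, strain ICR) with Mus musculus as the target, in the tail flick test, with a stated time of 90 min, at a dose of 25 umol/kg by the oral route (on this read-out lower numbers stand for a weaker effect and higher numbers for a stronger effect at the one dose given), the higher of the two numbers known so far. Compound 1 `CC(C)C[C@H](NC(=O)CN(c1nc(Cl)nc2[nH]cnc12)C1CC1)C(=O)OCc1ccccc1` gives 15.2%, and the step of a number 34.8 percentage points higher from compound 1 to compound 2 (beyond the scatter). Compound 3 `NC(=O)CC[C@H](NC(=O)CN(c1nc(Cl)nc2[nH]cnc12)C1CC1)C(=O)OCc1ccccc1` differs from compound 2 at another place: amino in place of benzyloxy on a carbonyl carbon. For the measured compounds named here, the one measured step exchanged the whole side chain rather than a group on the carbonyl carbon, so it bears only loosely on this change, and no measured step covers amino in place of benzyloxy. The step of a number 10 percentage points lower from compound 2 to compound 3 (within the scatter) is therefore expected to be small and uncertain. Compound 3 is estimated at 40%, between 15% and 65%.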

Compound 3, a percentage reported as activity, at one dose (the size of the read-out at that dose, not a potency): 42.8%
Beside the measured number, compound 3's estimate is 2.8 percentage points below it; measured number inside the range.
By their numbers in this assay, from the lowest: compound 1; then compounds 3 and 2 (each within the scatter of the next).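

In this assay, the step of a number 7.2 percentage points lower from compound 2 to compound 3 (within the scatter) shows that the benzyloxy on this carbonyl carbon can give way to amino, a much smaller group, without a change beyond the scatter. The step of a number 27.6 percentage points higher from compound 1 to compound 3 (beyond the scatter) shows that the gain over isopropyl does not depend on that benzyloxy, since carbamoylmethyl also gives it. No evidence on why the read-out behaves this way is at hand. From the compounds shown here alone, it remains open how a carboxylic acid or a dimethylamino group on this carbonyl carbon would read out.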